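Swapping the aryl on the amine: cytotoxicity outlook

A few compounds are considered here, and "the series" means these few. Any claim that something is new, unique, unknown or untested is made for them only; others in the source may bear on it.

compound 1 `O=C(O)c1ccc(-n2cc(CNc3ccc(F)c(C(F)(F)F)c3)c(-c3ccccc3)n2)cc1` — > 32 ug/mL
compound 2 `O=C(O)c1ccc(-n2cc(CNc3ccc(Br)c(C(F)(F)F)c3)c(-c3ccccc3)n2)cc1` — > 32 ug/mL

In an ADME assay on HEK293 cells (Homo sapiens) for cytotoxicity (a lower number here means that less compound is tolerated, a higher number that more compound is tolerated), compound 1 reaches only a limit of the assay, > 32 ug/mL. Compound 2 also sits at a limit of the assay, > 32 ug/mL. Among the compounds with values here, the single measured step, a step that the two limits leave unreadable from compound 1 to compound 2, cannot be read because of the limit of > 32 ug/mL in this assay, at which 2 of the 2 values shown sit. Compound 3 `O=C(O)c1ccc(-n2cc(CNc3ccc(Cl)c(Cl)c3)c(-c3ccccc3)n2)cc1` carries 3,4-dichlorophenyl in place of 4-bromo-3-(trifluoromethyl)phenyl on an amine nitrogen. Within the data shown here, only that unreadable step bears on this change, so no direction can be drawn from it, and no step beyond the scatter is expected; the estimated step is a step that the limit leaves unreadable from compound 2 to compound 3. Compound 3 is expected near 40 ug/mL, between 16 ug/mL and 100 ug/mL, most likely reported again as a limit.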

Compound 3, half-maximal cytotoxic concentration: 18 ug/mL
Beside the measured number, compound 3's estimate is 2.2-fold (0.35 log units) above it; low and high end bracket the measured number.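

In this assay, within the data shown here, compound 3 is the first in this set to give a number rather than a limit, which makes the 3,4-dichlorophenyl group on the amine nitrogen the first change here with a readable lower bound. That bound is an at least 1.7-fold lower number from compound 2 to compound 3 (0.24 log units; that floor lies within the scatter), and likewise an at least 1.7-fold lower number from compound 1 to compound 3 (0.24 log units; that floor lies within the scatter). Both steps are floors, so the true gaps may be larger, but neither is shown to exceed the scatter.

As far as these compounds go, it remains open how a plain phenyl or a methoxyphenyl group on that amine nitrogen would read in this assay.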